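Swapping a Thiophene for a Furan on the Core

The source may report more compounds than this note shows. Statements on the series, on what has been measured and on what is new or still open speak of the compounds shown alone.

Measured so far:
- Compound 1 `CSc1ccc(C2=C(c3ccccc3)C(=O)N3CCCC3C2)cc1`: 1000 nM
- Compound 2 `CSc1ccc(C2=C(c3ccncc3)C(=O)N3CCCC3C2)cc1`: 6000 nM
- Compound 3 `CSc1ccc(C2=C(c3cccs3)C(=O)N3CCCC3C2)cc1`: 270 nM

All three share one core and differ only in the aromatic ring attached to a double-bonded ring carbon. In a functional assay on HCT-116 cells (Homo sapiens) for cytotoxicity (on this read-out higher numbers stand for weaker inhibition and lower numbers for stronger inhibition), compound 3 stands lowest of the three numbers, that is, it is the strongest inhibitor shown. The step of a 3.7-fold lower number from compound 1 to compound 3 (0.57 log units; beyond the scatter) is modest, while a 22-fold lower number from compound 2 to compound 3 (1.35 log units; beyond the scatter) is large; the remaining step, a 6.0-fold higher number from compound 1 to compound 2 (0.78 log units; beyond the scatter), shows that a pyridine ring in that place gave the weakest result.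

Compound 4 `CSc1ccc(C2=C(c3ccco3)C(=O)N3CCCC3C2)cc1` is the next variation: furan-2-yl in place of thiophen-2-yl on a double-bonded ring carbon. For the measured compounds named here, no furan-bearing compound has been measured, so the only guidance comes from the steps just described, which show that the choice of ring at this carbon moves this assay by modest to large amounts. A furan is close in shape to a thiophene, so a small rise in the number, within or just beyond the scatter, seems most likely. For compound 4 the estimated value in this assay is 500 nM, with a range from 150 nM to 1700 nM. The expected step is therefore a 1.9-fold higher number from compound 3 to compound 4 (0.27 log units; within the scatter).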

Compound 4, half-maximal inhibitory concentration: 3000 nM
For compound 4 the middle estimate is 6.0-fold (0.78 log units) below the measured one; the whole stated range lies below it.
By their numbers in this assay, from the lowest: compound 3; then compound 1; then compounds 4 and 2 (each within the scatter of the next).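

At this double-bonded ring carbon, two five-membered aromatic rings of the same size are not interchangeable in this assay: furan-2-yl in place of thiophen-2-yl gives an 11-fold higher number from compound 3 to compound 4 (1.05 log units; beyond the scatter), so exchanging the one sulfur for an oxygen matters as much as the larger steps seen earlier. The furan-2-yl ring also compares poorly with phenyl, with a 3.0-fold higher number from compound 1 to compound 4 (0.48 log units; beyond the scatter), and it cannot be told apart from pyridin-4-yl, with a 2.0-fold lower number from compound 2 to compound 4 (0.30 log units; within the scatter), leaving thiophen-2-yl as the only ring here that improves on phenyl. Nothing available here explains why these two closely matched rings differ so much.

Still open, on these data alone, is whether the position of the sulfur matters, as in thiophen-3-yl, and whether a methyl group or an amine added to the thiophen-2-yl ring would preserve the result of compound 3 at 270 nM. As far as these compounds go, the rest of the shared core stays the same in all four compounds, so its part in the result also remains unknown.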